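Swapping allyl for phenyl on a triazole nitrogen: paw edema

The source may report more compounds than this note shows. Statements on the series, on what has been measured and on what is new or still open speak of the compounds shown alone.

Compound 2 `C=CCn1c(SCC(=O)c2ccccc2)nnc1-c1ccc(OC)c(OC)c1` and compound 1 `COc1ccc(-c2nnc(SCC(=O)c3ccccc3)n2-c2ccccc2)cc1OC` share one core and differ in a single spot, (phenyl in place of allyl on an aromatic nitrogen). In a functional assay on the whole organism (strain albino) for inhibition, with Rattus norvegicus as the target, read by paw edema, with a stated time of 1 h, at a dose of 0.28 mmol/kg by the oral route (a lower number here means less inhibition, a higher number more inhibition at the dose given (going by the name of the read-out)), compound 2 gives 61%, and compound 1 gives 56%, so the swap produced a number 5 percentage points lower from compound 2 to compound 1 (within the scatter), a step within the scatter. Compound 3 `C=CCn1c(SC/C(=N/O)c2ccccc2)nnc1-c1cc(OC)c(OC)c(OC)c1` carries a different core; how its core differs from that of compound 2 is not broken down here. In this assay compound 3 gives 61%, level with compound 2 at the digits printed and within the scatter of compound 1. Compound 4 `COc1cc(-c2nnc(SC/C(=N/O)c3ccccc3)n2-c2ccccc2)cc(OC)c1OC` is not yet measured. It relates to compound 3 as compound 1 relates to compound 2: phenyl in place of allyl on an aromatic nitrogen, the same change at the same place. Since the change made only a number 5 percentage points lower from compound 2 to compound 1 (within the scatter), the step of a number 4 percentage points lower from compound 3 to compound 4 (within the scatter) is expected to be of similar small size, resting on that one pair alone. Compound 4 is therefore estimated at 57%, between 47% and 67%.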

Compound 4, a percentage reported as inhibition, in the whole organism at one dose (the size of the read-out at that dose, not a potency): 61%
Compound 4: middle estimate off by 4 percentage points, on the low side; low and high end bracket the measured number.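

Putting phenyl in place of allyl on the aromatic nitrogen gives, in this assay, no change at the digits printed from compound 3 to compound 4 (within the scatter). Set beside the earlier pair, the swap reads the same on both cores: the same change on two cores in this assay, a number 5 percentage points lower (within the scatter) from compound 2 to compound 1 and no change at the digits printed (within the scatter) from compound 3 to compound 4, 5 percentage points apart, within the scatter of two such steps

So in these two pairs, phenyl and allyl on that nitrogen cannot be told apart by this read-out, and the swap carries from one core to the other without a step beyond the scatter, but this does not show that the two groups are equivalent in general, as it rests on two pairs, one dose and one time point, and a reading at one dose is not a potency.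

The compounds shown carry only allyl or phenyl on that nitrogen, so it stays open how a methyl, a longer chain such as butyl, or a benzyl would read there. From the compounds shown here alone, it also stays open whether a phenyl bearing an amine or a carboxylic acid would separate from the plain phenyl, and whether allyl and phenyl would part at other doses.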